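The source may hold more compounds than are shown below. What is called first, only, known or untested is meant among the compounds shown, and "the series" means these compounds.

In an assay on HL-60 cells for inhibition of glutathione S-transferase P (Homo sapiens) (a lower number here means a stronger inhibitor, a higher number a weaker inhibitor), compound 2 `C=C(CC)C(=O)c1ccc(OCc2nc(-c3ccc(F)cc3)no2)c(Cl)c1Cl` gives 3900 nM. Among the compounds with values here, the only other compound measured, compound 1 `C=C(CC)C(=O)c1ccc(OCc2nc(C)no2)c(Cl)c1Cl`, gives 4000 nM, and the two lie within the scatter of each other, so neither can be called the stronger inhibitor. Within the data shown here, the one measured step, a 1.0-fold lower number from compound 1 to compound 2 (0.01 log units; within the scatter), bears directly on the change to compound 3 `C=C(CC)C(=O)c1ccc(OCc2nc(-c3ccc(C(F)(F)F)cc3)no2)c(Cl)c1Cl`, which is trifluoromethyl in place of fluoro on an aromatic carbon. Because a 1.0-fold lower number from compound 1 to compound 2 (0.01 log units; within the scatter) moved nothing beyond the scatter even when methyl was swapped for a whole 4-fluorophenyl, a smaller alteration on that ring is expected to do little. Compound 3 is therefore estimated at 3500 nM, likely between 1500 nM and 8000 nM. The expected step is a 1.1-fold lower number from compound 2 to compound 3 (0.05 log units; within the scatter), within the scatter.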

Compound 3, half-maximal inhibitory concentration: > 40000 nM
Compound 3 gave a limit, no number (the forecaster's own chance of this, stated with the estimate: 5%); middle value at least 11-fold (1.05 log units) from the limit.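

In this assay compound 3 gives a limit, not a number: the limit of > 40000 nM in this assay, at which 1 of the 3 values shown sits. This position is therefore not indifferent to what it carries: trifluoromethyl in place of fluoro, para to a large group, gives an at least 10-fold higher number from compound 2 to compound 3 (1.01 log units; beyond the scatter). The large swap from methyl to 4-fluorophenyl changed nothing beyond the scatter, yet 4-(trifluoromethyl)phenyl in place of methyl gives an at least 10-fold higher number from compound 1 to compound 3 (1.00 log units; beyond the scatter).

From the compounds shown here alone, whether this loss belongs to trifluoromethyl alone stays open, and a chlorine atom, a methoxy group or an amine on that ring carbon would test it. Why this change matters cannot be told from these compounds.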